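The source may hold more compounds than are shown below. What is called first, only, known or untested is meant among the compounds shown, and "the series" means these compounds.

Measured compounds in an assay on SW1353 cells (Homo sapiens) for inhibition, read by a luciferase reporter, with stated times of 30 min and 8 h; on this read-out lower numbers stand for stronger inhibition and higher numbers for weaker inhibition:
compound 1, `O=c1sc2ccccc2n1CCCCN1CCN(CCCCn2c(=O)sc3ccccc32)CC1`: 2280 nM
compound 2, `O=c1sc2ccccc2n1CCCCN1CCN(CCCn2c(=O)sc3ccccc32)CC1`: 1710 nM
compound 3, `O=c1sc2ccccc2n1CCCCCCN1CCN(CCCCn2c(=O)sc3ccccc32)CC1`: 830 nM

The three compounds share a central ring amine carrying two arms, each ending in the same bicyclic group, and differ only in the length of those arms. Compound 2 and compound 1 differ by one change: a group of 11 heavy atoms (8 carbon, 1 nitrogen, 1 oxygen, 1 sulfur; one five-membered aromatic ring with 2 hetero atoms, one six-membered aromatic ring of carbon only) in place of a group of 10 heavy atoms (7 carbon, 1 nitrogen, 1 oxygen, 1 sulfur; one five-membered aromatic ring with 2 hetero atoms, one six-membered aromatic ring of carbon only), on a saturated chain carbon, three bonds along the chain from an amine nitrogen in a ring. In this assay this gave a 1.3-fold higher number from compound 2 to compound 1 (0.12 log units; within the scatter), so the two values cannot be told apart. Compound 1 and compound 3 also differ in one place, and here the move was larger: a 2.7-fold lower number from compound 1 to compound 3 (0.44 log units; beyond the scatter), a modest gain. Compound 3 and compound 2 differ in more than one place; the difference between their two cores is not broken down here, and their values alone show compound 3 with the lower number.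

Compound 4, `O=c1sc2ccccc2n1CCCCCCN1CCN(CCCCCn2c(=O)sc3ccccc32)CC1`, is not yet measured. It differs from compound 3 by a group of 11 heavy atoms (8 carbon, 1 nitrogen, 1 oxygen, 1 sulfur; one five-membered aromatic ring with 2 hetero atoms, one six-membered aromatic ring of carbon only) in place of a group of 10 heavy atoms (7 carbon, 1 nitrogen, 1 oxygen, 1 sulfur; one five-membered aromatic ring with 2 hetero atoms, one six-membered aromatic ring of carbon only), on a saturated chain carbon, four bonds along the chain from an amine nitrogen in a ring. For the measured compounds named here, this is the same kind of change as the one from compound 2 to compound 1, but not the same: there the change sat three bonds along the chain from the amine nitrogen in a ring, whereas here it sits four bonds along. Since the earlier instance gave only a 1.3-fold higher number from compound 2 to compound 1 (0.12 log units; within the scatter), a step within the scatter, compound 4 is expected to stay close to compound 3, with an estimated 1.1-fold higher number from compound 3 to compound 4 (0.06 log units; within the scatter). On that basis compound 4 is estimated at 950 nM in this assay, plausibly between 420 nM and 2100 nM.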

Compound 4, half-maximal inhibitory concentration: 1060 nM
Beside the measured number, compound 4's estimate is 1.1-fold (0.05 log units) below it; measured number inside the range.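

In this assay the group of 11 heavy atoms in place of the group of 10 heavy atoms, on a saturated chain carbon, four bonds along the chain from an amine nitrogen in a ring, gave a 1.3-fold higher number from compound 3 to compound 4 (0.11 log units; within the scatter) and so compound 3 and compound 4 cannot be told apart. Set beside the earlier instance of this kind of change, the new step agrees with it: the same change on two cores in this assay, a 1.3-fold higher number (0.12 log units; within the scatter) from compound 2 to compound 1 and a 1.3-fold higher number (0.11 log units; within the scatter) from compound 3 to compound 4, 1.0-fold (0.02 log units) apart, within the scatter of two such steps. For the compounds shown here, the change can therefore be carried between these two cores without a step beyond the scatter on either, but this rests on only two pairs, where a small step on each says little about what the change would do on a third core, and neither pair gives any sign that this kind of change shifts the number at all.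

The compounds shown leave open how far the arm length can go, for instance whether a longer chain on both arms of the central ring amine would keep the number near these values. They also leave open whether the same holds when a chain carries an amine or a carboxylic acid, or when a different end group replaces the shared bicyclic one.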